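This account rests on a few compounds, and the source may have more. Where it says the series, first, only, none or still open, it means among the compounds named here.

Working notes on the series. Compound 1 `C/C(=N\C(C)C)c1c(O)c2ccccc2[nH]c1=O` is the starting point. In an assay on isolated protein for inhibition of myosin-2 (Bos taurus), read by spectrophotometry, with a stated time of 24 min (on this read-out higher numbers stand for weaker inhibition and lower numbers for stronger inhibition), compound 1 gives only a limit, >= 100000 nM, not a number. This is the limit of >= 100000 nM in this assay, at which 1 of the 2 values shown sits. Among the compounds with values here, compound 2 `C/C(=N\Cc1cccnc1)c1c(O)c2ccccc2oc1=O` differs from compound 1 in more than one place, and in this assay compound 2 gives 17000 nM; no single step connects these two values, so they stand only as two readings side by side.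

The next compound to be measured is compound 3 `C/C(=N\CC(C)C)c1c(O)c2ccccc2[nH]c1=O`. The change from compound 1 to compound 3 is isobutyl in place of isopropyl on a double-bonded nitrogen. Within the data shown here, no step between measured compounds of this kind is available here. Since compound 1 sits at the limit (the limit of >= 100000 nM in this assay, at which 1 of the 2 values shown sits), a step in this assay of no size beyond the scatter is expected, with the reading likely to remain a limit. Compound 3 is estimated at 100000 nM in this assay, within 30000 nM to 300000 nM. The expected step is a number no higher from compound 1 to compound 3 (the limit leaves the size open).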

Compound 3, half-maximal inhibitory concentration: >= 100000 nM
Compound 3: a limit, no number (the forecaster's own chance of this, stated with the estimate: 65%); the middle value sits exactly at the limit.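

Compound 3, like compound 1, gives only a limit and no number in this assay, so no step can be read between the two: the limit of >= 100000 nM in this assay, at which 2 of the 3 values shown sit. The compounds shown leave open whether isobutyl and isopropyl differ at all in this read-out.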